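Replacing a Fused Bicycle with Anilino: Clearance Outlook

A few compounds are considered here, and "the series" means these few. Any claim that something is new, unique, unknown or untested is made for them only; others in the source may bear on it.

Three compounds were run in an ADME assay on microsomes from liver (Homo sapiens) for metabolic stability, read by LC-MS, using NADPH, with stated times of 5 min and 30 min, tested at 1 uM; a higher number here means faster removal of the compound, a lower number slower removal. Compound 1 `CN(C)C(=O)c1cc(-c2cnc(NCc3c(F)ccc4c3CCO4)c3cn[nH]c(=O)c23)n(C)n1` gives 21 mL.min-1.g-1, compound 3 `Cc1nc(CN(C)C)ccc1-c1cnc(NCc2c(F)ccc3c2CCO3)c2cn[nH]c(=O)c12` gives 13 mL.min-1.g-1, and compound 2 `O=C1c2ccccc2CN1c1cnc(NCc2c(F)ccc3c2CCO3)n2cnnc12` gives 13 mL.min-1.g-1, the same digits as compound 3; its gap to compound 1 lies within the scatter, so the three stand together. Going by the values given here, the one single-site step measured, a 1.6-fold lower number from compound 1 to compound 3 (0.21 log units; within the scatter), also stays within the scatter. Compound 4 `Fc1ccc2c(c1CNc1ncc(Nc3ccccc3)c3nncn13)CCO2` differs from compound 2 by a group of 7 heavy atoms (6 carbon, 1 nitrogen; one six-membered aromatic ring of carbon only) in place of a group of 10 heavy atoms (8 carbon, 1 nitrogen, 1 oxygen; one five-membered non-aromatic ring with 1 hetero atom, one six-membered aromatic ring of carbon only), on an aromatic carbon. Among the compounds with values here, no measured step touches this position, and the only step available was flat, so nothing in the data argues for a move beyond the scatter. Compound 4 is therefore expected to give 15 mL.min-1.g-1, within a range from 6 mL.min-1.g-1 to 40 mL.min-1.g-1. The expected step is a 1.2-fold higher number from compound 2 to compound 4 (0.06 log units; within the scatter).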

Compound 4, intrinsic clearance in microsomes: 20 mL.min-1.g-1
The estimate for compound 4 lay 1.3-fold (0.12 log units) below the measured number; the measured number falls inside the stated range.
By their numbers in this assay, from the lowest: compounds 2, 3, 4 and 1 (each within the scatter of the next).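

Anilino, in place of the group of 10 heavy atoms on this aromatic carbon, gives a 1.5-fold higher number from compound 2 to compound 4 (0.19 log units; within the scatter) in this assay. Going by these compounds alone, this is the first measured step at this position, and it shows that the exchange, which removes the five-membered non-aromatic ring and adds a hydrogen-bond donor, stays within the scatter. Nothing available accounts for the size of this step.

The compounds shown leave open whether morpholine or benzylamino at this position would also stay within the scatter. They also leave open how a fluorine or methoxy group on the anilino ring would read.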